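Exchanging One Aromatic Arm on a Shared Core

This account rests on a few compounds, and the source may have more. Where it says the series, first, only, none or still open, it means among the compounds named here.

Measured so far:
compound 1 `Cc1cc(NC(=O)Cn2nnc(-c3ccccc3)n2)n(C2CCS(=O)(=O)C2)n1`: 93%
compound 2 `Cc1cc(NC(=O)Cn2nnc(-c3cccc(Cl)c3)n2)n(C2CCCCC2)n1`: 89%

In an assay on HEK293 cells for activation of Kir3.1/Kir3.2 (Homo sapiens), read by thallium flux (on this read-out lower numbers stand for smaller maximal responses and higher numbers for larger maximal responses), compound 1 gives 93%, and compound 2 gives 89%. Compound 2 has the lower of the two numbers, but the gap to compound 1 lies within the usual scatter, so the two cannot be ranked; both reach most of the reference response.

Compound 3 `Cc1cc(NC(=O)Cn2nnc(-c3ccnc(F)c3)n2)n(C2CCCCC2)n1` differs from compound 2 in one place: 2-fluoropyridin-4-yl in place of 3-chlorophenyl on an aromatic carbon. For the measured compounds named here, no measured pair in this set shows what such an exchange does in this assay, and the two measured compounds sit close together, so there is no basis for expecting a large step in either direction; a change of none beyond the scatter, or a modest drop, is the expectation. Compound 3 is therefore expected to give about 85%, between 65% and 100%. The step of a number 4 percentage points lower from compound 2 to compound 3 (within the scatter) is expected to stay small.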

Compound 3, largest response reached (Emax), in percent of the reference or control that the assay uses: 95%
Beside the measured number, compound 3's estimate is 10 percentage points below it, and the stated range covers the measured number.
By their numbers in this assay, from the lowest: compounds 2, 1 and 3 (each within the scatter of the next).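

In this assay, for the compounds shown here, putting 2-fluoropyridin-4-yl in place of 3-chlorophenyl gives a number 6 percentage points higher from compound 2 to compound 3 (within the scatter), so this is the first direct view of a change at this aromatic carbon, and the maximal response stays within the scatter. The position therefore accepts a six-membered aromatic ring holding a nitrogen and a fluorine as well as an all-carbon ring bearing chlorine, even though the entering group counts a hydrogen-bond acceptor that the leaving group lacks. No separate measurement is available to explain why the response holds.

Since the ring nitrogen and the fluorine enter together, a plain pyridin-4-yl group would be needed to tell their contributions apart. Going by these compounds, whether this position needs an aromatic ring at all remains open, and a non-aromatic group such as an amine or a carboxylic acid there would test that.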